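Amine substituent swap on the shared core: compound 4

The compounds below may be only part of what the source reports. "The series", "measured", "known", "first", "only" and "open" are said of these compounds alone.

Compound 1 `CC(C)Sc1nnc(-c2c(CNC3CC3)c3ccccc3n2C)n1-c1ccccc1` has the lowest number of the three measured in a physicochemical assay for lipophilicity; on this read-out lower numbers stand for lower lipophilicity and higher numbers for higher lipophilicity: compound 1 gives 4.81, compound 3 `CC(C)Sc1nnc(-c2c(CNC3CC3)c3cc(F)ccc3n2C)n1-c1ccccc1` gives 4.97, and compound 2 `COc1cccc(CNCc2c(-c3nnc(SC(C)C)n3-c3ccccc3)n(C)c3ccc(F)cc23)c1` gives 6.42. The step of a number 0.16 log units higher from compound 1 to compound 3 (within the scatter) is within the scatter, whereas the step of a number 1.45 log units lower from compound 2 to compound 3 (beyond the scatter) is large. Compound 4 `CC1CN(Cc2c(-c3nnc(SC(C)C)n3-c3ccccc3)n(C)c3ccccc23)CC(C)O1` differs from compound 1 by 2,6-dimethylmorpholin-4-yl in place of cyclopropylamino on a saturated chain carbon bound to an aromatic carbon.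

Among the measured compounds shown here, only the step from compound 2 to compound 3 bears on this change, since it also alters the group on the amine nitrogen, and there the larger group went with a much higher number. The group entering compound 4 is larger than cyclopropylamino but brings an oxygen and takes away the hydrogen-bond donor, so a rise smaller than that step is expected. The estimate for compound 4 in this assay is therefore 5.4, within 4.9 to 5.9, which is expected to amount to a number 0.59 log units higher from compound 1 to compound 4 (beyond the scatter).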

Compound 4, partition coefficient: 5.13
Beside the measured number, compound 4's estimate is 0.27 log units above it; low and high end bracket the measured number.
By their numbers in this assay, from the lowest: compounds 1, 3 and 4 (each within the scatter of the next, the first and the last beyond it); then compound 2.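

At the saturated chain carbon bound to an aromatic carbon, this assay now gives a reading for a tertiary ring amine: 2,6-dimethylmorpholin-4-yl in place of cyclopropylamino gives a number 0.32 log units higher from compound 1 to compound 4 (beyond the scatter) and is a modest step. The exchange of cyclopropyl for 3-methoxybenzyl on the amine nitrogen, a number 1.45 log units lower from compound 2 to compound 3 (beyond the scatter) in the other pair, remains much the larger, so a larger group at this site need not bring a large step. Nothing shown accounts for the difference between these two steps.

As far as these compounds go, the oxygen, the two methyl groups and the loss of the hydrogen-bond donor all change together here, so their shares stay open; morpholin-4-yl and piperidin-1-yl would separate them. Also open, from the compounds shown here alone, is whether the same exchange gives a similar step on the fluoro-substituted core of compound 3.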